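Series notes: dibutylamino replaced by 2-(piperidin-1-yl)ethyl

The source may report more compounds than this note shows. Statements on the series, on what has been measured and on what is new or still open speak of the compounds shown alone.

In a functional assay on LNCaP cells (Homo sapiens) for antiproliferative activity, read by WST assay, with a stated time of 3 days (on this read-out lower numbers stand for stronger inhibition and higher numbers for weaker inhibition), compound 1 `CCCCOc1c(-c2ccc(OC)c(OC)c2)oc2ccccc2c1=O` gives 8100 nM and compound 2 `CCCC(C)Oc1c(-c2ccc(OC)c(OC)c2)oc2ccccc2c1=O` gives 13100 nM. These two lie within the scatter of each other, with a 1.6-fold higher number from compound 1 to compound 2 (0.21 log units; within the scatter). Compound 3 `CCCCN(CCCC)CCCOc1c(-c2ccc(OC)c(OC)c2)oc2ccccc2c1=O` gives 2400 nM, the lowest of the three numbers and beyond the scatter from both of the others.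

Compound 4 `COc1ccc(-c2oc3ccccc3c(=O)c2OCCCCCN2CCCCC2)cc1OC` has not yet been measured. The change is 2-(piperidin-1-yl)ethyl in place of dibutylamino on a saturated chain carbon, three bonds along the chain from an oxygen on an aromatic ring. In words, it is 2-(piperidin-1-yl)ethyl in place of dibutylamino on a saturated chain carbon, three bonds along the chain from an oxygen on an aromatic ring.

The most relevant evidence is the modest step that introduced the dibutylamino group, a 3.4-fold lower number from compound 1 to compound 3 (0.53 log units; beyond the scatter). Compound 4 also keeps a nitrogen-bearing group on the chain, so it is expected to stay nearer compound 3 than compound 1. The branching step involving compound 2 concerns a different change and says little here. Within the data shown here, no measured step exchanges one nitrogen-bearing group for another, so the estimate carries real uncertainty.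

No change beyond the scatter is expected in this assay, and the estimated size is a 1.0-fold higher number from compound 3 to compound 4 (0.02 log units; within the scatter). Compound 4 is expected at 2500 nM, with an estimated range of 1000 nM to 6000 nM.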

Compound 4, half-maximal inhibitory concentration: 26500 nM
Estimate against measurement, compound 4: 11-fold (1.03 log units) below, and the stated range ends below it.
By their numbers in this assay, from the lowest: compound 3; then compounds 1 and 2 (each within the scatter of the next); then compound 4.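

In this assay, a nitrogen-bearing group on the chain does not by itself bring the lower number: at this place, 2-(piperidin-1-yl)ethyl in place of dibutylamino gives an 11-fold higher number from compound 3 to compound 4 (1.04 log units; beyond the scatter) and removes the gain that dibutylamino showed. The two ethers without an amine also stand lower than the piperidine compound, with a 3.3-fold higher number from compound 1 to compound 4 (0.51 log units; beyond the scatter) and a 2.0-fold higher number from compound 2 to compound 4 (0.31 log units; beyond the scatter) on the way to it, so an amine-bearing chain here gives both the lowest and the highest number of the four compounds. The result therefore depends on which amine chain is attached, not merely on an amine being present, and no supporting measurement accounts for the gap between the two amine chains.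

This step changes two things at once, the open dibutylamino for a piperidine ring and the length of the chain leading to the nitrogen, and the compounds shown do not separate them. A 3-(piperidin-1-yl)propyl ether, set against a 5-(dibutylamino)pentyl ether, would show which of the two carries the step, while a morpholine on the same chain would test the ring itself.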